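Pyridin-3-yl for 4-chlorophenyl on a piperazine-bearing benzamide

This account rests on a few compounds, and the source may have more. Where it says the series, first, only, none or still open, it means among the compounds named here.

Measured compounds and their values in a functional assay on HeLa cells (Homo sapiens) for antiproliferative activity, read by CCK-8 assay, with a stated time of 72 h, tested at 8 uM; a lower number here means a weaker effect, a higher number a stronger effect of the compound at the concentration tested:
compound 1, `Nc1ccccc1NC(=O)c1ccc(CSC(=S)N2CCN(Cc3ccccn3)CC2)cc1`, gives 61.4%
compound 2, `Nc1ccccc1NC(=O)c1ccc(CSC(=S)N2CCN(c3ccc(Cl)cc3)CC2)cc1`, gives 44.8%
compound 3, `Nc1ccccc1NC(=O)c1ccc(CSC(=S)N2CCc3ccccc32)cc1`, gives 67%

Compound 2 stands lowest of the three numbers in this assay; the nearest is compound 1, which lies above it beyond the scatter, and compound 3 lies furthest above it, also beyond the scatter. Among the measured compounds shown here, the one measured step that reaches compound 2 is a number 16.6 percentage points lower from compound 1 to compound 2 (beyond the scatter), where a 4-chlorophenyl group replaced (pyridin-2-yl)methyl on the amine nitrogen in the ring.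

Compound 4, `Nc1ccccc1NC(=O)c1ccc(CSC(=S)N2CCN(c3cccnc3)CC2)cc1`, is not yet measured. It differs from compound 2 in one place: pyridin-3-yl in place of 4-chlorophenyl on an amine nitrogen in a ring. This change bears on the step from compound 1 to compound 2, in that a nitrogen-containing aromatic group returns to the ring nitrogen, though here pyridin-3-yl is attached directly rather than through a methylene. The step from compound 1 to compound 2 was modest and downward, so a modest upward step from compound 2 to compound 4 is expected in this assay, of about a number 10.2 percentage points higher from compound 2 to compound 4 (beyond the scatter). Compound 4 is therefore estimated to give 55% in this assay, within a range from 40% to 70%.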

Compound 4, a percentage reported as inhibition, at one concentration (the size of the read-out at that concentration, not a potency): 72.5%
Compound 4: middle estimate off by 17.5 percentage points, on the low side, outside the stated range (above it).
By their numbers in this assay, from the lowest: compound 2; then compounds 1, 3 and 4 (each within the scatter of the next, the first and the last beyond it).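

In this assay, pyridin-3-yl in place of 4-chlorophenyl gives a number 27.7 percentage points higher from compound 2 to compound 4 (beyond the scatter), so an aromatic ring attached directly to the amine nitrogen does not in itself keep the number low. The methylene of (pyridin-2-yl)methyl is not needed for a high number either, since the directly attached pyridin-3-yl gives a number 11.1 percentage points higher from compound 1 to compound 4 (beyond the scatter), although that step also moves the ring nitrogen of the pyridine. Nothing at hand accounts for either step.

The compounds shown leave open whether the rise from the chlorinated ring follows from the pyridine nitrogen or from the loss of chlorine, a question that a plain phenyl on the same amine nitrogen would separate. As far as these compounds go, it also remains open how pyridin-4-yl or pyridin-2-yl, attached directly, would compare with pyridin-3-yl.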